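The compounds below may be only part of what the source reports. "The series", "measured", "known", "first", "only" and "open" are said of these compounds alone.

Measured in a functional assay on MCF7 cells (Homo sapiens) for antiproliferative activity, read by MTT assay, with a stated time of 72 h; a higher number here means a weaker inhibitor, a lower number a stronger inhibitor:

Compound 1 `O=C1O[C@H]([C@@H](O)Cn2cc(-c3cccc(O)c3)nn2)C(OCc2ccccc2)=C1OCc1ccccc1`: 51800 nM
Compound 2 `CCCCc1cn(C[C@H](O)[C@H]2OC(=O)C(OCc3ccccc3)=C2OCc2ccccc2)nn1`: 7910 nM
Compound 3 `CCCCCc1ccc(-c2cn(C[C@H](O)[C@H]3OC(=O)C(OCc4ccccc4)=C3OCc3ccccc3)nn2)cc1`: 9010 nM

Compound 3 stands second highest of the three numbers. Its nearest neighbour is compound 2: the step of a 1.1-fold higher number from compound 2 to compound 3 (0.06 log units; within the scatter) lies within the scatter. Its furthest is compound 1: the step of a 5.7-fold lower number from compound 1 to compound 3 (0.76 log units; beyond the scatter) lies beyond it.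

Compound 4 `COc1ccccc1-c1cn(C[C@H](O)[C@H]2OC(=O)C(OCc3ccccc3)=C2OCc2ccccc2)nn1` differs from compound 3 in one place: 2-methoxyphenyl in place of 4-pentylphenyl on an aromatic carbon. For the measured compounds named here, two measured steps bear on this. The step of a 5.7-fold lower number from compound 1 to compound 3 (0.76 log units; beyond the scatter) shows that replacing a ring bearing a hydroxyl with a plain 4-pentylphenyl lowered the number, while the step of a 1.1-fold higher number from compound 2 to compound 3 (0.06 log units; within the scatter) shows that butyl and 4-pentylphenyl give like numbers. Going by the values given here, no measured step tests a 2-methoxyphenyl itself. Among the compounds with values here, the only measured aryl group carrying an oxygen is the 3-hydroxyphenyl of compound 1, which gives 51800 nM in this assay. A modest rise is therefore expected, and compound 4 is estimated to move by a 2.2-fold higher number from compound 3 to compound 4 (0.35 log units; beyond the scatter). In this assay compound 4 is expected to give about 20000 nM, within a range of 7000 nM to 60000 nM.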

Compound 4, half-maximal inhibitory concentration: > 100000 nM
Compound 4 ended at the assay's limit; the forecaster's own chance of this, stated with the estimate: 10%; middle value at least 5.0-fold (0.69 log units) away from the limit.
By their numbers in this assay, from the lowest: compounds 2 and 3 (each within the scatter of the next); then compound 1. At a limit, above all of these: compound 4.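

Compound 3 and compound 2 had suggested that this aromatic carbon takes butyl and 4-pentylphenyl alike, but compound 4 shows that it does not accept every group. Setting 2-methoxyphenyl in place of 4-pentylphenyl gives an at least 11-fold higher number from compound 3 to compound 4 (1.04 log units; beyond the scatter), and setting it in place of butyl gives an at least 12-fold higher number from compound 2 to compound 4 (1.10 log units; beyond the scatter), so an aromatic ring at this place does not by itself keep the number low. Setting 2-methoxyphenyl in place of 3-hydroxyphenyl gives an at least 1.9-fold higher number from compound 1 to compound 4 (0.28 log units; that floor lies within the scatter), so this step does not show that compound 4 stands apart from compound 1. The value of compound 4 is a limit and not a number, so all three steps are floors: the limit of > 100000 nM in this assay, at which 1 of the 4 values shown sits.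

On these data alone, whether the methoxy group itself or its place on the ring goes with this rise stays open. So does whether a plain phenyl or a 4-methoxyphenyl would give a number like that of compound 3 or a limit like that of compound 4.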